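Swapping Cyclopropylpropyl for Methoxymethylpropyl on the Core

A few compounds are considered here, and "the series" means these few. Any claim that something is new, unique, unknown or untested is made for them only; others in the source may bear on it.

Going by the values given here, compound 1 `CC[C@H](C1CC1)n1c(=O)c(C)nc2c(-c3cc(F)c(OC)cc3Cl)ccnc21` gives the lowest number of the three measured so far, 1.7 nM in a functional assay for antagonist activity at corticotropin-releasing factor receptor 1 (Rattus norvegicus); a lower number here means a stronger inhibitor, a higher number a weaker inhibitor. Compound 3 `CC[C@H](C1CC1)n1c(=O)c(C)nc2c(-c3cc(C)c(OC)nc3C)ccnc21` gives 15 nM, and compound 2 `CC[C@H](COC)n1c(=O)c(C)nc2c(-c3ccc(Cl)cc3Cl)ncnc21` gives 97 nM; both gaps from compound 1 lie beyond the scatter. Compound 4 `CCC(COC)n1c(=O)c(C)nc2c(-c3cc(F)c(OC)cc3Cl)ccnc21` differs from compound 1 by 1-(methoxymethyl)propyl in place of 1-cyclopropylpropyl on an aromatic nitrogen. Among the compounds with values here, no pair of measured compounds isolates this change; compound 2 carries the same entering group but also a different core and a different aryl ring, and its value shows only that the whole combination is weaker than compound 1. A moderate loss is expected, of roughly a 3.5-fold higher number from compound 1 to compound 4 (0.55 log units; beyond the scatter). Compound 4 is estimated at 6 nM, with a range from 2 nM to 25 nM.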

Compound 4, half-maximal inhibitory concentration: 2.1 nM
For compound 4 the middle estimate is 2.9-fold (0.46 log units) above the measured one, within the range that was stated.
By their numbers in this assay, from the lowest: compounds 1 and 4 (each within the scatter of the next); then compound 3; then compound 2.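

In this assay, 1-(methoxymethyl)propyl in place of 1-cyclopropylpropyl on the aromatic nitrogen gives a 1.2-fold higher number from compound 1 to compound 4 (0.09 log units; within the scatter), so the two groups cannot be told apart on this core with this aryl ring. At this position, the three-membered ring of carbon is therefore not required for a low number, and a ring-free group with one hydrogen-bond acceptor serves equally well. No measurement shown here accounts for this result. On these data alone, whether a longer chain, such as 1-(ethoxymethyl)propyl, or an amine in the same chain would fare alike remains open.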